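This account rests on a few compounds, and the source may have more. Where it says the series, first, only, none or still open, it means among the compounds named here.

Measured compounds:
compound 1 `CCN1CCC(c2c[nH]c3ccc(NC(=O)c4ccc(F)cc4)nc23)CC1` gives 170 nM in an assay for binding affinity to 5-hydroxytryptamine receptor 1F (Homo sapiens), read by radioligand binding; on this read-out higher numbers stand for weaker inhibition and lower numbers for stronger inhibition
compound 2 `CCCN1CCC(c2c[nH]c3ccc(NC(=O)c4ccc(F)cc4)nc23)CC1` gives 18 nM in this assay

For the measured compounds named here, compound 2 stands at the lowest of the two numbers in this assay; the single measured step, a 9.4-fold lower number from compound 1 to compound 2 (0.98 log units; beyond the scatter), lies beyond the scatter. Compound 3 `CCCCN1CCC(c2c[nH]c3ccc(NC(=O)c4ccc(F)cc4)nc23)CC1` has not yet been measured. It differs from compound 2 by methyl in place of hydrogen on a saturated chain carbon, three bonds along the chain from an amine nitrogen in a ring, which continues the chain lengthening of the measured step. As far as these compounds go, that step bears on the new one, but whether a further extension carries on in the same way is unknown. The step expected is a 1.5-fold lower number from compound 2 to compound 3 (0.18 log units; within the scatter), a small further decrease if any. Compound 3 is therefore estimated at 12 nM, within 4 nM to 40 nM.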

Compound 3, inhibition constant: 14 nM
The estimate for compound 3 lay 1.2-fold (0.07 log units) below the measured number; the range from low to high includes it.
By their numbers in this assay, from the lowest: compounds 3 and 2 (each within the scatter of the next); then compound 1.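

In this assay, methyl in place of hydrogen three bonds along the chain from the amine nitrogen in the ring gives a 1.3-fold lower number from compound 2 to compound 3 (0.11 log units; within the scatter), so the clear shift seen with the previous extension does not recur at this position. The butyl chain nevertheless keeps its distance from the ethyl chain, with a 12-fold lower number from compound 1 to compound 3 (1.08 log units; beyond the scatter). Nothing measured here explains this levelling off. The compounds shown leave open whether a pentyl chain, a branched isobutyl chain or a benzyl group on the same nitrogen would hold this level in this assay.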